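Triazolyl Spiro Series: Halogenated Phenyl Variant on Hepatoma Cells

The source may hold more compounds than are shown below. What is called first, only, known or untested is meant among the compounds shown, and "the series" means these compounds.

Compound 1 `Cc1cccc(-n2nncc2CN2C(=O)C3(C(C#N)=C(N)Oc4c3c3nc5ccccc5nc3c3ccccc43)c3ccccc32)c1` has so far given only a limit in a functional assay on HepG2 cells (Homo sapiens) for antiproliferative activity, read by MTT assay, with a stated time of 48 h; on this read-out lower numbers stand for stronger inhibition and higher numbers for weaker inhibition: its value of > 50000 nM is a boundary of the assay, not a number. Compound 2 `N#CC1=C(N)Oc2c(c3nc4ccccc4nc3c3ccccc23)C12C(=O)N(Cc1cnnn1-c1cccc(Cl)c1)c1ccccc12`, carrying chloro in place of methyl on an aromatic carbon, likewise returns only a limit, > 50000 nM. Compound 3 `COc1ccccc1-n1nncc1CN1C(=O)C2(C(C#N)=C(N)Oc3c2c2nc4ccccc4nc2c2ccccc32)c2ccccc21`, with 2-methoxyphenyl in place of 3-methylphenyl on an aromatic nitrogen, also gives a limit of > 50000 nM. All three values rest at the limit of > 50000 nM in this assay, at which 3 of the 3 values shown sit, so the steps a step that the two limits leave unreadable from compound 1 to compound 2, a step that the two limits leave unreadable from compound 1 to compound 3 and a step that the two limits leave unreadable from compound 2 to compound 3 cannot be read in size or direction; nothing separates the three compounds on these numbers.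

Compound 4 `N#CC1=C(N)Oc2c(c3nc4ccccc4nc3c3ccccc23)C12C(=O)N(Cc1cnnn1-c1ccc(F)c(Cl)c1)c1ccccc12` is the next member. The change from compound 1 is 3-chloro-4-fluorophenyl in place of 3-methylphenyl on an aromatic nitrogen. Within the data shown here, of the measured steps, the one from compound 1 to compound 2 bears most on it, since it too introduces chloro, but it is unreadable. Among the measured compounds shown here, no measured step shows any movement within this set, so the expected step is a step that the limit leaves unreadable from compound 1 to compound 4, meaning no change beyond the scatter, with the result most likely to be another limit. Compound 4 is therefore expected near 60000 nM in this assay, with a range from 20000 nM to 200000 nM.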

Compound 4, half-maximal inhibitory concentration: > 50000 nM
Compound 4: a limit, no number; the forecaster's own chance of this, stated with the estimate: 85%; the middle value does not contradict the limit.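

In this assay compound 4 gives > 50000 nM, a limit and not a number. The steps joining compound 4 to compound 1, compound 2 and compound 3 therefore cannot be read in size or direction: the limit of > 50000 nM in this assay, at which 4 of the 4 values shown sit.

The compounds shown leave open whether any of these phenyl variants on the shared core differs from another in this assay.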